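The source may hold more compounds than are shown below. What is called first, only, known or untested is meant among the compounds shown, and "the series" means these compounds.

Compound 1, `Cc1[nH]c(=O)n(C)c1-c1ccccc1`, has no definite number in a functional assay on brain (Rattus norvegicus, strain Wistar) for inhibition; on this read-out lower numbers stand for stronger inhibition and higher numbers for weaker inhibition. For compound 1 the result is > 100000 nM, which is a limit of the assay rather than a measured value, as also recorded in the limit of > 100000 nM in this assay, at which 1 of the 2 values shown sits. Compound 2, `Cc1[nH]c(=O)n(C2CCCCC2)c1-c1ccccc1`, differs from compound 1 by cyclohexyl in place of methyl on an aromatic nitrogen; in this assay compound 2 gives 47600 nM, and the step is an at least 2.1-fold lower number from compound 1 to compound 2 (0.32 log units; beyond the scatter). Compound 3, `CCCCCCc1ccc(-c2c(C)[nH]c(=O)n2C)cc1`, has not yet been measured. It differs from compound 1 in one place: hexyl in place of hydrogen on an aromatic carbon. Within the data shown here, the only measured step, the one from compound 1 to compound 2, concerns a different place on the shared core, so it bears on compound 3 only loosely, as a sign that adding a larger group can lower the number. The step expected for compound 3 is therefore an at least 2.5-fold lower number from compound 1 to compound 3 (0.39 log units; beyond the scatter), modest and toward a lower number. Compound 3 is estimated at 40000 nM, with a range from 10000 nM to 160000 nM.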

Compound 3, half-maximal inhibitory concentration: 9000 nM
For compound 3 the middle estimate is 4.4-fold (0.65 log units) above the measured one; the measured number lies below the stated range.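

Compound 2 showed a lower number only for a change on an aromatic nitrogen, whereas compound 3 shows that an aromatic carbon of the six-membered aromatic ring of carbon only is also a place where a change can lower the number in this assay. Hexyl in place of hydrogen there gives an at least 11-fold lower number from compound 1 to compound 3 (1.04 log units; beyond the scatter), which counts as a large step. Compound 1 stands at a limit of the assay, and the full size of the step stays unknown: the limit of > 100000 nM in this assay, at which 1 of the 3 values shown sits.

The compounds shown leave open whether a shorter chain such as butyl or a longer chain such as octyl would lower the number as hexyl does, and whether an amine at the end of the chain would keep the gain. They also leave open whether hexyl and cyclohexyl together would lower the number further.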